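The compounds below may be only part of what the source reports. "The series", "measured", "known", "first", "only" and "open" are said of these compounds alone.

Compound 1 `CC(C)C(c1ccc(-c2ccc3cccc(F)c3c2)[nH]c1=O)C1SC(=O)NC1=O`: 1.87 h
Compound 2 `O=C1NC(=O)/C(=C/C(c2ccc(-c3ccc4cccc(F)c4c3)[nH]c2=O)C2CC2)O1`: 1.98 h

Both values come from an ADME assay on microsomes from liver (Homo sapiens) for metabolic stability; on this read-out higher numbers stand for a longer-lived compound and lower numbers for a shorter-lived compound. Compound 1, at 1.87 h, stands level with compound 2, since the two numbers lie within the usual scatter of repeated measurements and cannot be told apart.

The compound to be tested next is compound 3 `CC(C)C(/C=C1/C(=O)NC(=O)N1C)c1ccc(-c2ccc3cccc(F)c3c2)[nH]c1=O`. It keeps the core of compound 1 but loses the 2,4-dioxo-1,3-thiazolidin-5-yl group: a group of 9 heavy atoms (5 carbon, 2 nitrogen, 2 oxygen; one five-membered non-aromatic ring with 2 hetero atoms) in place of a group of 7 heavy atoms (3 carbon, 1 nitrogen, 2 oxygen, 1 sulfur; one five-membered non-aromatic ring with 2 hetero atoms), on a saturated chain carbon bound to an aromatic carbon and a saturated chain carbon.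

For the measured compounds named here, no measured pair isolates this kind of swap, so the data offer only a weak guide. The two compounds in hand, compound 1 at 1.87 h and compound 2 at 1.98 h, sit within the scatter of each other, so no step beyond the scatter is expected in this assay in either direction. The expected step is a 1.1-fold higher number from compound 1 to compound 3 (0.03 log units; within the scatter). For compound 3 the estimated half-life is 2 h, with an expected range of 1 h to 4 h.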

Compound 3, half-life: > 3 h
Compound 3 ended at the assay's limit; the forecaster's own chance of this, stated with the estimate: 5%; at least 1.5-fold (0.17 log units) between middle value and limit.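

Compound 3 reads > 3 h in this assay, and this is a limit of the assay, not a number. Exchanging the 2,4-dioxo-1,3-thiazolidin-5-yl group for a sulfur-free ring group of 9 heavy atoms on this saturated chain carbon gives an at least 1.6-fold higher number from compound 1 to compound 3 (0.20 log units; that floor lies within the scatter), so the half-life holds up under this change, although the printed floor alone does not establish a real gain. As far as these compounds go, the full size of the step remains unknown because the read-out stops at a limit: the limit of > 3 h in this assay, at which 1 of the 3 values shown sits.

The compounds shown leave open whether the loss of sulfur, the added atoms or the extra double bond outside aromatic rings accounts for the step. They also do not tell how an amine or a carboxylic acid on this carbon would behave in this assay.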